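Methyl for isopropyl on a benzimidazole nitrogen

The source may report more compounds than this note shows. Statements on the series, on what has been measured and on what is new or still open speak of the compounds shown alone.

Compound 1 `Cn1c(/C=C2\SC(=O)N(CC(=O)N3CCCCC3)C2=O)nc2ccccc21` and compound 2 `CC(C)n1c(/C=C2\SC(=O)N(CC(=O)N3CCCCC3)C2=O)nc2ccccc21` share one core and differ only by methyl in place of isopropyl on an aromatic nitrogen. In a functional assay on PC-3 cells (Homo sapiens) for inhibition, read by MTT assay, with a stated time of 48 h (a higher number here means a weaker inhibitor, a lower number a stronger inhibitor), compound 1 gives only a limit, > 50000 nM. Compound 2 likewise gives only a limit, > 50000 nM. The step between them is therefore a step that the two limits leave unreadable from compound 2 to compound 1. Compound 3 `COc1cc2c(cc1OC)CN(C(=O)CN1C(=O)S/C(=C\c3nc4ccccc4n3C(C)C)C1=O)CC2` carries another core; how its core differs from that of compound 2 is not broken down here. In this assay compound 3 also gives only a limit, > 50000 nM. Compound 4 `COc1cc2c(cc1OC)CN(C(=O)CN1C(=O)S/C(=C\c3nc4ccccc4n3C)C1=O)CC2` is not yet measured and differs from compound 3 by methyl in place of isopropyl on an aromatic nitrogen, the same change as that from compound 2 to compound 1. For compound 4 the expected step is a step that the limit leaves unreadable from compound 3 to compound 4, and it is expected to stay unreadable because of the limit of > 50000 nM in this assay, at which 3 of the 3 values shown sit. Compound 4 is therefore estimated at 80000 nM, with a range from 20000 nM to 300000 nM, and most likely again only a limit.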

Compound 4, half-maximal inhibitory concentration: 41100 nM
Compound 4: middle estimate off by 1.9-fold (0.29 log units), on the high side; the measured number falls inside the stated range.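

In this assay, going by these compounds alone, methyl in place of isopropyl on the aromatic nitrogen gives an at least 1.2-fold lower number from compound 3 to compound 4 (0.08 log units; that floor lies within the scatter), so on the core of compound 3 the only reading is a floor that lies within the scatter. This shows that compound 4 has a measured value on this core, but it does not show a real gain in inhibition. The same change on the core of compound 2 cannot be read, and whether its size carries from one core to the other stays unknown because nearly all values here are limits: the limit of > 50000 nM in this assay, at which 3 of the 4 values shown sit.

Still open, on these data alone, is whether a longer chain such as n-butyl, or a benzyl group, on that aromatic nitrogen would give a value clear of the limit. Also open, as far as these compounds go, is what an amine or a carboxylic acid in the side chain would do in this assay.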